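The compounds below may be only part of what the source reports. "The series", "measured", "known", "first", "only" and "open" are said of these compounds alone.

Of the three compounds measured in a functional assay on HL-60 cells (Homo sapiens) for inhibition, read by CCK-8 assay, with a stated time of 48 h (on this read-out higher numbers stand for weaker inhibition and lower numbers for stronger inhibition), only compound 3 `O=C(NCCNS(=O)(=O)c1ccc(-c2ccccc2Oc2ccc([N+](=O)[O-])c([N+](=O)[O-])c2)s1)Nc1ccc(Cl)cc1` yields a number: in this assay compound 3 gives 8100 nM. Compound 1 `Nc1ccc(Oc2ccccc2-c2ccc(S(=O)(=O)NCCNC(=O)Nc3ccc(Cl)cc3)s2)cc1` reaches only a limit, > 50000 nM in this assay. Compound 2 `O=[N+]([O-])c1ccc(NC(=S)NCCNS(=O)(=O)c2ccc(-c3ccccc3OCc3ccccc3)s2)cc1` likewise stops at the limit > 50000 nM. This is the limit of > 50000 nM in this assay, at which 2 of the 3 values shown sit. For the measured compounds named here, the one measured step, an at least 6.1-fold lower number from compound 1 to compound 3 (0.79 log units; beyond the scatter), concerns the oxygen on an aromatic ring and not the amide-type nitrogen. Compound 4 `COc1cccc(NC(=O)NCCNS(=O)(=O)c2ccc(-c3ccccc3Oc3ccc([N+](=O)[O-])c([N+](=O)[O-])c3)s2)c1` differs from compound 3 by 3-methoxyphenyl in place of 4-chlorophenyl on an amide-type nitrogen. No measured step touches this place, so the shown values give no direction for it, and the expected step is a 1.2-fold higher number from compound 3 to compound 4 (0.09 log units; within the scatter), within the scatter. Compound 4 is therefore estimated at 10000 nM, between 3000 nM and 40000 nM.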

Compound 4, half-maximal inhibitory concentration: 6700 nM
Compound 4: middle estimate off by 1.5-fold (0.17 log units), on the high side; the range from low to high includes it.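

The place on the amide-type nitrogen now has its first measured step: in this assay, 3-methoxyphenyl in place of 4-chlorophenyl gives a 1.2-fold lower number from compound 3 to compound 4 (0.08 log units; within the scatter) and so stays within the scatter. With the 3,4-dinitrophenyl group held fixed, this exchange of one substituted phenyl for another thus separates the two compounds by no more than repeated measurements would. Nothing shown gives a cause for this result.

Still open, from the compounds shown here alone, is whether a longer chain in place of the phenyl, or an amine or a carboxylic acid on it, would keep the number at this level. Also open, going by these compounds, is whether the same exchange reads alike with 4-aminophenyl on the oxygen.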